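Dimethylamino for tert-butyl: a step without a direct precedent

The compounds below may be only part of what the source reports. "The series", "measured", "known", "first", "only" and "open" are said of these compounds alone.

Compound 1, `Cc1ccc(C(=O)NN2C(=O)NC3(CC3(C)C)C2=O)cc1`: 100 mg/kg
Compound 2, `CC(C)(C)c1ccc(C(=O)NN2C(=O)NC3(CC3(C)C)C2=O)cc1`: 30 mg/kg
Compound 3, `COc1cc(C(=O)NN2C(=O)NC3(CC3(C)C)C2=O)cc(OC)c1OC`: 300 mg/kg

All doses come from a functional assay on the whole organism (Hindlimb) for inhibition, with Mus musculus as the target, with a stated time of 0.5 h; a lower number here means that less compound is needed, a higher number that more compound is needed for the effect. Compound 2 has the lowest number of the three: the step of a 3.3-fold lower number from compound 1 to compound 2 (0.52 log units; beyond the scatter) lies beyond the scatter, and compound 3 sits higher still. Compound 4, `CN(C)c1ccc(C(=O)NN2C(=O)NC3(CC3(C)C)C2=O)cc1`, shares the core and differs from compound 2 in one place: dimethylamino in place of tert-butyl on an aromatic carbon. Among the measured compounds shown here, no measured pair swaps these two groups, so the only guide is a 3.3-fold lower number from compound 1 to compound 2 (0.52 log units; beyond the scatter), where a larger group at this spot gave the lower number. Dimethylamino is counted smaller than tert-butyl, so the step of a 3.3-fold higher number from compound 2 to compound 4 (0.52 log units; beyond the scatter) is expected to go toward a higher number, partly undoing that gain. Compound 4 is therefore estimated at 100 mg/kg, within 30 mg/kg to 300 mg/kg.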

Compound 4, minimum effective dose: 300 mg/kg
The estimate for compound 4 lay 3.0-fold (0.48 log units) below the measured number; the measured number falls inside the stated range.
By their numbers in this assay, from the lowest: compound 2; then compound 1; then compounds 3 and 4 (each within the scatter of the next).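

Two groups larger than methyl now pull in opposite directions on this aromatic carbon: tert-butyl lowered the dose, while dimethylamino gives a 3.0-fold higher number from compound 1 to compound 4 (0.48 log units; beyond the scatter). Putting dimethylamino in place of tert-butyl gives a 10-fold higher number from compound 2 to compound 4 (1.00 log units; beyond the scatter), so group size alone does not set the dose here. Nothing measured here explains why this step goes the way it does. The compounds shown leave open whether the nitrogen or the shape of the group matters more. A simple amine or an isopropyl group on the same carbon could help separate the two.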